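From Cyclopropyl to Hydroxyethyl on a Serine Amide

The source may report more compounds than this note shows. Statements on the series, on what has been measured and on what is new or still open speak of the compounds shown alone.

The study begins with compound 1 `C=C(C)C(=O)N[C@@H](CO)C(=O)O` and compound 2 `O=C(N[C@@H](CO)C(=O)O)C1CC1`, which share a core and differ only in the group on the carbonyl carbon. In an ADME assay on microsomes from liver (Homo sapiens) for metabolic stability, with a stated time of 30 min (a lower number here means that less of the compound is left, a higher number that more of the compound is left), compound 1 gives 82%. In this assay compound 2 gives 26%. Among the compounds with values here, the single measured step between them shows a number 56 percentage points lower from compound 1 to compound 2 (beyond the scatter). Compound 2 therefore stands lowest of the two numbers, with compound 1 as its nearest neighbour and well above it.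

The next compound, compound 3 `O=C(CCO)N[C@@H](CO)C(=O)O`, has not yet been measured. It differs from compound 2 as follows: 2-hydroxyethyl in place of cyclopropyl on a carbonyl carbon. Within the data shown here, the only measured step concerns a different exchange at the same carbonyl carbon, so it bears on this change only by showing that the group on that carbon can move the number a great deal. Among the measured compounds shown here, no measured step involves 2-hydroxyethyl. Compound 3 is therefore expected to give 45%, within 15% to 80%. That estimate means a step of a number 19 percentage points higher from compound 2 to compound 3 (beyond the scatter), expected to point upward but uncertain in size.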

Compound 3, percent of the compound remaining: 96%
Compound 3: middle estimate off by 51 percentage points, on the low side; measured number above the stated range.
By their numbers in this assay, from the lowest: compound 2; then compound 1; then compound 3.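

In this assay, the group on the carbonyl carbon decides much of the outcome even when its size barely changes: cyclopropyl and 2-hydroxyethyl both have 3 heavy atoms, yet the exchange gives a number 70 percentage points higher from compound 2 to compound 3 (beyond the scatter). What differs is that the three-membered ring is gone and the new chain carries an oxygen, with 1 hydrogen-bond donor and 1 hydrogen-bond acceptor, and 2-hydroxyethyl also compares well with 1-methylethenyl, giving a number 14 percentage points higher from compound 1 to compound 3 (beyond the scatter), so compound 3 stands highest of the three, with its steps to both others beyond the scatter. Nothing available here says what lies behind these steps.

The compounds shown cannot separate the loss of the ring from the arrival of the hydroxyl group, since both happen in the same exchange; a plain ethyl or propyl chain on the same carbonyl carbon would pull those two apart. They also leave open whether the high number survives in a longer chain such as 3-hydroxypropyl, or when the hydroxyl gives way to a methoxy group, an amine or a carboxylic acid.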